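The source may hold more compounds than are shown below. What is called first, only, known or untested is meant among the compounds shown, and "the series" means these compounds.

Three compounds have so far been measured in an assay on HEK293 cells for displacement of a labelled ligand from metabotropic glutamate receptor 5 (Homo sapiens), with a stated time of 2 h; on this read-out higher numbers stand for weaker inhibition and lower numbers for stronger inhibition:

Compound 1, `Cc1cccc(C#Cc2ccc3c(n2)CCN(C)C3=O)c1`, gives 820 nM.
Compound 2, `Cc1ccc(C#Cc2ccc3c(n2)CCN(C)C3=O)cc1`, gives 7450 nM.
Compound 3, `Cc1cccc(C#Cc2ccc3c(n2)CCN(C2CCCC2)C3=O)c1`, gives 670 nM.

Compound 1 and compound 2 share one core and differ only in the group on the triple bond: 4-methylphenyl in place of 3-methylphenyl on a triple-bonded carbon. That single change gave a 9.1-fold higher number from compound 1 to compound 2 (0.96 log units; beyond the scatter), so the 4-methylphenyl compound is the weaker binder of the two in this assay.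

Compound 3 carries the same 3-methylphenyl group as compound 1, but its core is altered at the amide-type nitrogen: cyclopentyl in place of methyl on an amide-type nitrogen in a ring. The effect of that change is a 1.2-fold lower number from compound 1 to compound 3 (0.09 log units; within the scatter), which means compound 1 and compound 3 cannot be told apart on this read-out.

Compound 4, `Cc1ccc(C#Cc2ccc3c(n2)CCN(C2CCCC2)C3=O)cc1`, has not yet been measured. It stands to compound 3 as compound 2 stands to compound 1: 4-methylphenyl in place of 3-methylphenyl on a triple-bonded carbon. The surroundings of the change are the same in both pairs, so this is the same change made on the cyclopentyl core instead of the methyl core. Among the measured compounds shown here, with only one prior example to go on, the expectation is that compound 4 shows a step of about a 9.0-fold higher number from compound 3 to compound 4 (0.95 log units; beyond the scatter) in this assay, because the same change produced a 9.1-fold higher number from compound 1 to compound 2 (0.96 log units; beyond the scatter) and the two cores behaved alike in a 1.2-fold lower number from compound 1 to compound 3 (0.09 log units; within the scatter). On that basis compound 4 is estimated at 6000 nM, with a likely range from 2500 nM to 15000 nM.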

Compound 4, inhibition constant: > 32000 nM
Compound 4: no number, only a limit; the forecaster's own chance of this, stated with the estimate: 5%; middle value at least 5.3-fold (0.72 log units) away from the limit.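

Compound 4 gives > 32000 nM in this assay, which is a limit of the assay and not a number. Going from 3-methylphenyl to 4-methylphenyl raises the number on both cores, but on the cyclopentyl core the change gives an at least 47-fold higher number from compound 3 to compound 4 (1.67 log units; beyond the scatter), so its size did not carry over from the methyl core: the same change on two cores in this assay, a 9.1-fold higher number (0.96 log units; beyond the scatter) from compound 1 to compound 2 and an at least 47-fold higher number (1.67 log units; beyond the scatter) from compound 3 to compound 4, at least 5.2-fold (0.72 log units) apart, beyond the scatter of two such steps

Seen from the other side, cyclopentyl in place of methyl gives an at least 4.2-fold higher number from compound 2 to compound 4 (0.63 log units; beyond the scatter), whereas compound 1 and compound 3 cannot be told apart, so in this small set the two changes do not simply add up, although two pairs of compounds cannot show why this happens or whether it holds beyond them: the same change on two cores in this assay, a 1.2-fold lower number (0.09 log units; within the scatter) from compound 1 to compound 3 and an at least 4.2-fold higher number (0.63 log units; beyond the scatter) from compound 2 to compound 4, at least 5.2-fold (0.72 log units) apart, beyond the scatter of two such steps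

The compounds shown leave open whether a methoxy group or a chlorine atom in place of the methyl on the phenyl ring would respond to the core in the same way. They also leave open whether an ethyl group or a longer chain on the amide-type nitrogen would behave like methyl or like cyclopentyl when paired with 4-methylphenyl.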